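The source may hold more compounds than are shown below. What is called first, only, known or untested is meant among the compounds shown, and "the series" means these compounds.

Working notes on the series.

Compound 1 `COc1ccc(C(=O)CSc2nnc(-c3cc(OC)c(OC)c(OC)c3)n2-c2ccc(OC)cc2)cc1` carries a methoxy on the outer aryl ketone. In a functional assay on HT-29 cells (Homo sapiens) for inhibition, read by MTT assay, with a stated time of 48 h (a higher number here means a weaker inhibitor, a lower number a stronger inhibitor), compound 1 gives only a limit, > 60000 nM, and no number. Compound 2 `COc1ccc(-n2c(SCC(=O)c3ccc(F)cc3)nnc2-c2cc(OC)c(OC)c(OC)c2)cc1` differs from compound 1 by fluoro in place of methoxy on an aromatic carbon; in this assay compound 2 gives 42500 nM. The step reads an at least 1.4-fold lower number from compound 1 to compound 2 (0.14 log units; that floor lies within the scatter), and its floor rests on the limit of compound 1, (the limit of > 60000 nM in this assay, at which 1 of the 3 values shown sits).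

Compound 3 `COc1ccc(C(=O)CSc2nnc(-c3cc(OC)c(OC)c(OC)c3)n2-c2ccc(N(C)C)cc2)cc1` has a different core, separated from the core of compound 1 by dimethylamino in place of methoxy on an aromatic carbon; the step that the limit leaves unreadable from compound 1 to compound 3 cannot be sized. In this assay compound 3 gives 64000 nM, a number that sits within the scatter of compound 2.

Compound 4 `COc1cc(-c2nnc(SCC(=O)c3ccc(F)cc3)n2-c2ccc(N(C)C)cc2)cc(OC)c1OC` is not yet measured. It differs from compound 3 by fluoro in place of methoxy on an aromatic carbon, the same change as that from compound 1 to compound 2, made on the core of compound 3. Since the earlier step was only a floor set by a limit, compound 4 is expected to move by roughly a 1.4-fold lower number from compound 3 to compound 4 (0.15 log units; within the scatter), a small step at the edge of the scatter. The expected value for compound 4 in this assay is 45000 nM, most likely between 20000 nM and 90000 nM.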

Compound 4, half-maximal inhibitory concentration: 78100 nM
For compound 4 the middle estimate is 1.7-fold (0.24 log units) below the measured one, within the range that was stated.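

Working from the readable steps in this assay, replacing methoxy with fluoro, 4-methoxyphenyl to 4-fluorophenyl, on the core of compound 3 gives a 1.2-fold higher number from compound 3 to compound 4 (0.09 log units; within the scatter), while dimethylamino in place of methoxy on an aromatic carbon gives a 1.8-fold higher number from compound 2 to compound 4 (0.26 log units; within the scatter). Neither step lies beyond the scatter, so the series does not show that the change carries from one core to another with a fixed size or direction, and it does not show that the two cores respond differently. Set side by side, the two steps read: the same change on two cores in this assay, an at least 1.4-fold lower number (0.14 log units; that floor lies within the scatter) from compound 1 to compound 2 and a 1.2-fold higher number (0.09 log units; within the scatter) from compound 3 to compound 4; the limit leaves it open whether they differ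

The compounds shown leave open whether another group on the aromatic carbon that carries the methoxy or fluoro, such as an amine or a carboxylic acid, would give a step beyond the scatter in this assay. They also leave open whether a longer chain in place of ((4-fluorophenyl)carbonyl)methyl would do so on either core.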